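Methoxy to ethoxy on the core: compound 4

The source may hold more compounds than are shown below. What is called first, only, known or untested is meant among the compounds shown, and "the series" means these compounds.

Measured so far in an assay on isolated protein for inhibition of high affinity 3',5'-cyclic-AMP phosphodiesterase 7A (Homo sapiens), read by cAMP accumulation, with a stated time of 10 min; a higher number here means a weaker inhibitor, a lower number a stronger inhibitor:
compound 1 `COc1nc2c(c(=O)n(C)c(=O)n2C)n1CC(=O)Nc1cccc(Cl)c1` > 200000 nM
compound 2 `COc1nc2c(c(=O)n(C)c(=O)n2C)n1CC(=O)Nc1ccc(C(C)C)cc1` > 200000 nM
compound 3 `COc1nc2c(c(=O)n(C)c(=O)n2C)n1CC(=O)NCc1ccccc1Cl` > 200000 nM

Compound 1 stands only at a limit of this assay; its value > 200000 nM is a limit and not a number. The same holds for compound 2, whose result is a limit. For compound 3 likewise the result is a limit. All three share the core of compound 1 and differ only in the group on the amide-type nitrogen; the steps a step that the two limits leave unreadable from compound 1 to compound 2, a step that the two limits leave unreadable from compound 1 to compound 3 and a step that the two limits leave unreadable from compound 2 to compound 3 are unreadable, because of the limit of > 200000 nM in this assay, at which 3 of the 3 values shown sit.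

Compound 4 `CCOc1nc2c(c(=O)n(C)c(=O)n2C)n1CC(=O)Nc1cccc(Cl)c1` carries the change (methyl in place of hydrogen on a saturated chain carbon bound to an oxygen on an aromatic ring), that is methoxy to ethoxy on the core, while the 3-chlorophenyl on the amide-type nitrogen is kept from compound 1. Within the data shown here, no measured step in this assay touches this position, so the pair compound 1 to compound 4 has no direct precedent here. The three limits show no inhibition resolved in this series at any of the amide variations tried, and a methyl added on the chain carbon bound to the ring oxygen is a small change.

Compound 4 is therefore expected to stay at a limit as well, with an estimated value of 300000 nM (range 100000 nM to 1000000 nM). The step this estimate means, a step that the limit leaves unreadable from compound 1 to compound 4, is expected to be none beyond the scatter.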

Compound 4, half-maximal inhibitory concentration: > 200000 nM
Compound 4: a limit, no number (the forecaster's own chance of this, stated with the estimate: 85%); the middle value is on the limit's open side.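

The result for compound 4 in this assay is a limit and not a number, as is that for compound 1, so methoxy to ethoxy on the core gives no readable step, because every value shown rests at one limit: the limit of > 200000 nM in this assay, at which 4 of the 4 values shown sit. The compounds shown leave open whether any change to the shared core or the amide group gives a numerical value in this assay.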